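Shortening a biphenyl to a tolyl on a pyrrolidine diol core

This account rests on a few compounds, and the source may have more. Where it says the series, first, only, none or still open, it means among the compounds named here.

Among the measured compounds shown here, in an assay on isolated protein for inhibition of alpha-galactosidase (Coffea arabica), read by spectrophotometry, tested at 1000 uM (on this read-out higher numbers stand for more inhibition at the one concentration tested (going by the name of the read-out) and lower numbers for less inhibition), compound 1 `O[C@@H]1[C@@H](O)CN[C@H]1c1ccc(-c2ccccc2)cc1` gives 0.3%, the higher of the two numbers known, though its nearest neighbour compound 2 `O[C@H]1[C@H](CCCc2ccccc2)NC[C@@H]1O` gives 0% in this assay, and the two lie within the scatter of each other. Compound 3 `Cc1ccc([C@@H]2NC[C@H](O)[C@H]2O)cc1` has not yet been measured. It differs from compound 1 by methyl in place of phenyl on an aromatic carbon. Since both measured compounds sit at the floor of this assay, the step from compound 1 to compound 3 is expected to be none beyond the scatter, namely a number 0.2 percentage points higher from compound 1 to compound 3 (within the scatter). Compound 3 is therefore estimated to give 0.5% in this assay, within a range of 0% to 8%.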

Compound 3, a percentage reported as inhibition, at one concentration (the size of the read-out at that concentration, not a potency): 0%
Estimate against measurement, compound 3: 0.5 percentage points above; measured number inside the range.
By their numbers in this assay, from the lowest: compounds 2, 3 and 1 (each within the scatter of the next).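

In this assay, the exchange of phenyl for methyl on this aromatic carbon gives a number 0.3 percentage points lower from compound 1 to compound 3 (within the scatter), so the step stays within the scatter. The second aromatic ring of compound 1 therefore makes no readable difference at this position, and a single methyl there reads the same as the phenyl. Nothing available bears on why the two compounds read alike.

As far as these compounds go, whether a hydroxyl group, an amine or a carboxylic acid on this carbon would lift the reading beyond the scatter stays open. The same holds for a longer chain in that place.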